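Methoxy Addition Across Two Cores: Working Notes

This account rests on a few compounds, and the source may have more. Where it says the series, first, only, none or still open, it means among the compounds named here.

Compound 1 `C=C(Br)C(=O)Nc1ccc(C(=O)/C=C/c2ccc(OC)cc2)cc1` and compound 2 `C=C(Br)C(=O)Nc1ccc(C(=O)/C=C/c2ccc(OC)c(OC)c2)cc1` share one core; compound 3 `Nc1ccc(C(=O)/C=C/c2ccccc2)cc1` and compound 4 `COc1ccccc1/C=C/C(=O)c1ccc(N)cc1` share another. In an ADME assay on CCRF-CEM cells (Homo sapiens) for antiproliferative activity, with a stated time of 48 h (a lower number here means a stronger inhibitor, a higher number a weaker inhibitor), compound 1 gives 1100 nM, compound 2 gives 1600 nM and compound 3 gives 8500 nM, the highest number of the three. The change from compound 1 to compound 2 is methoxy in place of hydrogen on an aromatic carbon and it brought a 1.5-fold higher number from compound 1 to compound 2 (0.16 log units; within the scatter). The difference between the two cores is not broken down here. Compound 4 arises from compound 3 by methoxy in place of hydrogen on an aromatic carbon, the same kind of change, but here the methoxy enters ortho to a large group, whereas in compound 2 it sits ortho to a methoxy group and meta to a large group. A similarly small step is expected because a 1.5-fold higher number from compound 1 to compound 2 (0.16 log units; within the scatter) stayed within the scatter, so the estimate is a 1.1-fold lower number from compound 3 to compound 4 (0.03 log units; within the scatter). Compound 4 is estimated at 8000 nM, between 4000 nM and 16000 nM.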

Compound 4, half-maximal inhibitory concentration: 6300 nM
For compound 4 the middle estimate is 1.3-fold (0.10 log units) above the measured one; the measured number falls inside the stated range.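

In this assay, methoxy in place of hydrogen on an aromatic carbon gives a 1.3-fold lower number from compound 3 to compound 4 (0.13 log units; within the scatter), and this step does not differ from the earlier one on the other core: the same change on two cores in this assay, a 1.5-fold higher number (0.16 log units; within the scatter) from compound 1 to compound 2 and a 1.3-fold lower number (0.13 log units; within the scatter) from compound 3 to compound 4, 2.0-fold (0.29 log units) apart, within the scatter of two such steps. Within these two cores, then, the change leaves the number within the scatter each time, and neither step can be told from no change. This rests on one pair per core, with the methoxy placed differently in each, so it does not show that the step holds at other ring positions or on further cores.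

Open, as far as these compounds go, is whether a hydroxy group, a chlorine atom or a longer alkoxy chain in place of the methoxy would give steps of similar size on both cores. Also open, from the compounds shown here alone, is what part of the gap between the two cores comes from each of their differences.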